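A few compounds are considered here, and "the series" means these few. Any claim that something is new, unique, unknown or untested is made for them only; others in the source may bear on it.

In an ADME assay on Vero 76 cells (Chlorocebus sabaeus) for cytotoxicity, read by crystal violet staining, with a stated time of 96 h (on this read-out higher numbers stand for lower toxicity in this test and lower numbers for higher toxicity in this test), compound 1 `O=[N+]([O-])c1ccc(NC(=S)Nc2cccc(C(F)(F)F)c2)cc1` gives 10000 nM. Compound 3 `Fc1cccc(NC(=S)Nc2cccc(C(F)(F)F)c2)c1` gives 20000 nM in this assay, and the two numbers lie within the usual scatter of each other, so neither can be placed above the other. Compound 2 `CC(=O)NC(=S)Nc1cccc(C(F)(F)F)c1` reaches only the limit of this assay, > 100000 nM. Within the data shown here, the one measured step, an at least 5.0-fold lower number from compound 2 to compound 3 (0.69 log units; beyond the scatter), rests on (the limit of > 100000 nM in this assay, at which 1 of the 3 values shown sits). Compound 4 `CCCC[C@H]1CC[C@H](c2ccc(NC(=S)Nc3cccc(C(F)(F)F)c3)cc2)CC1` differs from compound 1 at another place: 4-butylcyclohexyl in place of nitro on an aromatic carbon. Among the measured compounds shown here, no measured step touches that position, so nothing here sets the size of the step. The step of a 1.4-fold lower number from compound 1 to compound 4 (0.15 log units; within the scatter) is therefore expected to stay within the scatter. Compound 4 is estimated at 7000 nM, between 2000 nM and 30000 nM.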

Compound 4, half-maximal cytotoxic concentration: 17000 nM
Estimate against measurement, compound 4: 2.4-fold (0.39 log units) below; measured number inside the range.
By their numbers in this assay, from the lowest: compounds 1, 4 and 3 (each within the scatter of the next). At a limit, above all of these: compound 2.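

Putting 4-butylcyclohexyl in place of nitro on this aromatic carbon gives a 1.7-fold higher number from compound 1 to compound 4 (0.23 log units; within the scatter) in this assay and so the two compounds cannot be told apart on this read-out. This holds even though the entering group is all carbon, has no hydrogen-bond acceptors and is far larger than nitro. No measured property bears on this result. The compounds shown leave open whether an amine or a carboxylic acid on this carbon would give a similar number, and whether a plain butyl chain without the ring would.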